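A few compounds are considered here, and "the series" means these few. Any claim that something is new, unique, unknown or untested is made for them only; others in the source may bear on it.

Of the compounds shown here, three built on one shared core have been tested in a functional assay on SK-MEL-28 cells (Homo sapiens) for cytotoxicity, read by sulforhodamine B assay, with a stated time of 48 h, tested at 100 uM; a lower number here means a stronger effect, a higher number a weaker effect of the compound at the concentration tested. Compound 1 `COc1ccc(-c2cc(/C=C/C(=O)c3ccc(N)cc3)[nH]n2)cc1` gives -81%, compound 2 `COc1cc(-c2cc(/C=C/C(=O)c3ccc(N)cc3)[nH]n2)cc(OC)c1OC` gives -83%, and compound 3 `COc1ccc(C(=O)/C=C/c2cc(-c3cc(OC)c(OC)c(OC)c3)n[nH]2)cc1OC` gives -90%. Compound 2 thus sits close to both others, its number within the usual scatter of compound 1 and of compound 3 alike. Among the compounds with values here, the single measured step, a number 7 percentage points lower from compound 2 to compound 3 (within the scatter), stays within the scatter. Compound 4 `COc1ccc(-c2cc(/C=C/C(=O)c3ccc(N)cc3)[nH]n2)cc1OC` differs from compound 2 by hydrogen in place of methoxy on an aromatic carbon, ortho to a methoxy group. Within the data shown here, no measured step removes a methoxy group, though compound 1 and compound 2, which differ in their methoxy groups, show nearly the same number. A step no larger than the scatter is therefore expected, and compound 4 is estimated at -81%, within -91% to -70%, an expected a number 2 percentage points higher from compound 2 to compound 4 (within the scatter).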

Compound 4, a percentage reported as activity, at one concentration (the size of the read-out at that concentration, not a potency): -93%
For compound 4 the middle estimate is 12 percentage points above the measured one, outside the stated range (below it).
By their numbers in this assay, from the lowest: compounds 4, 3, 2 and 1 (each within the scatter of the next, the first and the last beyond it).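

Methoxy in place of hydrogen on this aromatic carbon gives a number 12 percentage points lower from compound 1 to compound 4 (beyond the scatter), the first step in the series to pass the scatter, whereas hydrogen in place of methoxy gives a number 10 percentage points lower from compound 2 to compound 4 (within the scatter). The number therefore does not simply follow the count of methoxy groups, since compound 4 carries fewer of them than compound 2 and more than compound 1. What lies behind these steps remains unexplained, as nothing at hand bears on them. On these data alone, it stays open whether a hydroxy group or a chlorine atom at this position would match methoxy or hydrogen.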